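The source may report more compounds than this note shows. Statements on the series, on what has been measured and on what is new or still open speak of the compounds shown alone.

Three compounds have been measured in an ADME assay on microsomes from liver (Homo sapiens) for metabolic stability, tested at 2.5 uM; a lower number here means slower removal, a higher number faster removal of the compound:

Compound 1, `Cc1ccc(S(=O)(=O)c2cnc3c(F)cccc3c2-c2cccc(F)c2)cc1F`, gives 3.92 mL/min.
Compound 2, `COc1cccc(-c2c(S(=O)(=O)c3ccc(C)c(F)c3)cnc3c(F)cccc23)c1`, gives 4.02 mL/min.
Compound 3, `COc1ccc(S(=O)(=O)c2cnc3c(F)cccc3c2-c2cccc(OC)c2)cc1`, gives 2.87 mL/min.

Compound 2 has the highest of the three numbers, yet its nearest neighbour is compound 1, with a 1.0-fold higher number from compound 1 to compound 2 (0.01 log units; within the scatter), and the furthest is compound 3, with a 1.4-fold lower number from compound 2 to compound 3 (0.15 log units; within the scatter), so all three sit within the usual scatter of one another and no real order can be read from them.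

Compound 4, `Cc1ccc(S(=O)(=O)c2cnc3c(F)cccc3c2-c2ccc(F)cc2)cc1F`, has not yet been measured. It differs from compound 2 in one place: 4-fluorophenyl in place of 3-methoxyphenyl on an aromatic carbon. Among the compounds with values here, the measured step that bears on this is the one from compound 1 to compound 2, where a methoxy replaced a fluoro on an aromatic carbon and gave a 1.0-fold higher number from compound 1 to compound 2 (0.01 log units; within the scatter). Within the data shown here, the step to compound 4 runs the other way, a fluoro in place of a methoxy, and shifts the position of the substituent on that ring, but the one comparison available shows no change beyond the scatter. No step beyond the scatter is therefore expected in this assay for compound 4, and the estimated step is a 1.0-fold lower number from compound 2 to compound 4 (0.01 log units; within the scatter). Compound 4 is expected to give about 3.9 mL/min, within a range of 2.4 mL/min to 6.3 mL/min.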

Compound 4, intrinsic clearance in a liver preparation (reported as CLH), per the amount of preparation that the assay uses: 2.75 mL/min
Compound 4: the middle estimate sits 1.4-fold (0.15 log units) above what was measured, and the stated range covers the measured number.
By their numbers in this assay, from the lowest: compounds 4, 3, 1 and 2 (each within the scatter of the next).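

In this assay, three different phenyl groups can now be compared at this position on the shared core, all with the same 3-fluoro-4-methylphenyl group on the sulfonyl sulfur. Placing 4-fluorophenyl where 3-methoxyphenyl stood gives a 1.5-fold lower number from compound 2 to compound 4 (0.16 log units; within the scatter) and placing it where 3-fluorophenyl stood gives a 1.4-fold lower number from compound 1 to compound 4 (0.15 log units; within the scatter) so the earlier finding that methoxy and fluoro on this ring read alike now extends to a change in where the fluoro sits, since both steps stay within the usual scatter of the measurement. No further data are available to explain why the number stays so flat across these groups.

On these data alone, all the groups at this position are phenyl rings with a single fluoro or methoxy, so it remains open whether a basic amine, a carboxylic acid or a nitrile on that ring, or a saturated ring such as morpholine in place of it, would produce a step beyond the scatter. The other end of the molecule is also barely explored, with only 4-methoxyphenyl and 3-fluoro-4-methylphenyl on the sulfonyl sulfur.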